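This account rests on a few compounds, and the source may have more. Where it says the series, first, only, none or still open, it means among the compounds named here.

Of the compounds shown here, three have so far been tested in a functional assay on CCRF-CEM cells (Homo sapiens) for antiproliferative activity, read by fluorescence and resazurin assay, with a stated time of 48 h (on this read-out higher numbers stand for weaker inhibition and lower numbers for stronger inhibition), and give numbers of a similar order. Compound 1 (`CCOc1ccc(NC(=O)c2cc3cc(Br)ccc3oc2=O)cc1`) gives 21800 nM in this test, the highest of the three numbers. Compound 2 (`CCOc1ccc2nc(Cl)c(/C=N/NC(=O)c3cc4cc([N+](=O)[O-])ccc4oc3=O)cc2c1`) at 15700 nM cannot be told apart from it, given the usual scatter of repeated measurements. Compound 3 (`O=C(N/N=C/c1cccnc1)c1cc2ccccc2oc1=O`) gives 9900 nM as its number, and this gap to compound 1 lies beyond the scatter.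

Compound 4 (`CCOc1ccc(NC(=O)c2cc3ccccc3oc2=O)cc1`) is compound 1 with a single change to the shared core: hydrogen in place of bromo on an aromatic carbon. The rest of the molecule stays the same. Among the compounds with values here, no measured pair here isolates this change, so the data give no direct measure of it. Compound 3 also carries hydrogen there, with 9900 nM as its value, but it differs from compound 1 elsewhere too and is only a loose guide. The expectation in this assay is no step beyond the scatter, with no firm direction. The estimated step of a 1.1-fold lower number from compound 1 to compound 4 (0.04 log units; within the scatter) is accordingly small. Compound 4 is expected at 20000 nM within an estimated range of 8000 nM to 50000 nM overall.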

Compound 4, half-maximal inhibitory concentration: 17900 nM
Estimate against measurement, compound 4: 1.1-fold (0.05 log units) above, and the stated range covers the measured number.
By their numbers in this assay, from the lowest: compounds 3, 2, 4 and 1 (each within the scatter of the next, the first and the last beyond it).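

Within the data shown here, replacing bromo with hydrogen on this aromatic carbon gives, in (this assay), a 1.2-fold lower number from compound 1 to compound 4 (0.09 log units; within the scatter) as the first step in this set that isolates one change while the rest of the molecule stays the same. At this position on this molecule, then, the loss of the single bromine atom leaves no difference that can be told apart from the usual variation between repeated measurements, so bromo is not shown here to be needed for the antiproliferative effect or to add to it. No supporting measurement is available to explain why the two numbers lie so close.

The compounds shown leave open whether a different group on this same aromatic carbon, such as an amine, a carboxylic acid or a methoxy group, would move the number beyond the scatter in either direction. One pair also cannot tell whether bromo and hydrogen would remain this close in molecules that differ elsewhere, so this result applies only to the core and side chain of compound 1.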